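A few compounds are considered here, and "the series" means these few. Any claim that something is new, unique, unknown or untested is made for them only; others in the source may bear on it.

Compound 1 `CCOC(=O)CNC(=O)NC1=CS(=O)(=O)O[C@@]12[C@@H](CO[Si](C)(C)C(C)(C)C)O[C@@H](n1cc(C)c(=O)n(C)c1=O)[C@@H]2O[Si](C)(C)C(C)(C)C`: 13000 nM
Compound 2 `COC(=O)NC1=CS(=O)(=O)O[C@@]12[C@@H](CO[Si](C)(C)C(C)(C)C)O[C@@H](n1cc(C)c(=O)n(C)c1=O)[C@@H]2O[Si](C)(C)C(C)(C)C`: > 200000 nM (a limit)
Compound 3 `Cc1cn([C@@H]2O[C@H](CO[Si](C)(C)C(C)(C)C)[C@@]3(OS(=O)(=O)C=C3NC(=O)NC(=O)c3ccccc3)[C@H]2O[Si](C)(C)C(C)(C)C)c(=O)n(C)c1=O`: >= 200000 nM (a limit)

These values come from a functional assay on HEL cells (Homo sapiens); on this read-out lower numbers stand for higher toxicity in this test and higher numbers for lower toxicity in this test. Compound 3 stands at >= 200000 nM, which is a limit and not a number. Compound 4 `COC(=O)CCNC1=CS(=O)(=O)O[C@@]12[C@@H](CO[Si](C)(C)C(C)(C)C)O[C@@H](n1cc(C)c(=O)n(C)c1=O)[C@@H]2O[Si](C)(C)C(C)(C)C` differs from it as follows: 2-(methoxycarbonyl)ethyl in place of benzoylcarbamoyl on an amine nitrogen. Within the data shown here, two measured steps bear on this change, and both are large and beyond the scatter: an at least 15-fold higher number from compound 1 to compound 3 (1.18 log units; beyond the scatter) and an at least 15-fold higher number from compound 1 to compound 2 (1.18 log units; beyond the scatter). Only compound 1, with its (ethoxycarbonyl)methyl group, gives a true number, and the new 2-(methoxycarbonyl)ethyl chain resembles that group by name. Among the measured compounds shown here, no measured compound carries this exact chain, so a clear but uncertain move toward lower numbers, meaning higher toxicity, is expected: an at least 4.0-fold lower number from compound 3 to compound 4 (0.60 log units; beyond the scatter). The estimate for compound 4 is 50000 nM, with an expected range from 10000 nM to 200000 nM.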

Compound 4, half-maximal cytotoxic concentration: 94000 nM
For compound 4 the middle estimate is 1.9-fold (0.27 log units) below the measured one, and the stated range covers the measured number.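

In this assay, a carbamoyl-free chain on the amine nitrogen still brings the number down from the limits of compounds 2 and 3, which are limits and not true numbers: an at least 2.1-fold lower number from compound 3 to compound 4 (0.32 log units; beyond the scatter) and an at least 2.1-fold lower number from compound 2 to compound 4 (0.32 log units; beyond the scatter). So the toxicity seen at this position does not depend on a carbonyl group attached directly to that nitrogen. Even so, the chain falls short of compound 1, with a 7.2-fold higher number from compound 1 to compound 4 (0.86 log units; beyond the scatter).

On these data alone, it remains open what the ester at the chain end contributes. A carboxylic acid or an amine in its place, or a longer chain, would test this.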